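Swapping the pendant aryl group on the shared core

This account rests on a few compounds, and the source may have more. Where it says the series, first, only, none or still open, it means among the compounds named here.

Compound 3 `CC/C(=C(/c1ccc(/C=C/C(=O)O)cc1)c1cc2ccccc2[nH]1)c1cccc(OC(F)(F)F)c1` gives 282 nM in a functional assay on MCF7 cells (Homo sapiens) for inhibition (on this read-out higher numbers stand for weaker inhibition and lower numbers for stronger inhibition), the highest number among the three measured compounds; compound 1 `CC/C(=C(/c1ccc(/C=C/C(=O)O)cc1)c1cc2ccccc2[nH]1)c1ccccc1C#N` gives 9 nM and compound 2 `CC/C(=C(/c1ccc(/C=C/C(=O)O)cc1)c1cc2ccccc2[nH]1)c1ccccc1C(F)(F)F` gives 8 nM in this assay, and these two sit within the scatter of each other (a 1.1-fold lower number from compound 1 to compound 2 (0.05 log units; within the scatter)). Compound 4 `CC/C(=C(/c1ccc(/C=C/C(=O)O)cc1)c1cc2ccccc2[nH]1)c1ccc(Cl)cc1` differs from compound 3 in one place: 4-chlorophenyl in place of 3-(trifluoromethoxy)phenyl on a double-bonded chain carbon bound to a double-bonded chain carbon and a saturated chain carbon. Among the measured compounds shown here, no measured step exchanges a 3-(trifluoromethoxy)phenyl for a 4-chlorophenyl, so the nearest guide is the pair of steps that replaced a 2-cyanophenyl or a 2-(trifluoromethyl)phenyl on the same chain carbon with the 3-(trifluoromethoxy)phenyl of compound 3, namely a 31-fold higher number from compound 1 to compound 3 (1.50 log units; beyond the scatter) and a 35-fold higher number from compound 2 to compound 3 (1.55 log units; beyond the scatter). Both were large. Because compound 3 gives 282 nM while compound 1 gives 9 nM and compound 2 gives 8 nM, the measured numbers span a wide stretch, and a 4-chlorophenyl that is again a single six-membered carbon ring is expected to land between those extremes rather than beyond either of them. Compound 4 is therefore estimated at 80 nM in this assay, within a range of 20 nM to 400 nM, which would mean an expected step of a 3.5-fold lower number from compound 3 to compound 4 (0.55 log units; beyond the scatter).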

Compound 4, half-maximal inhibitory concentration: 343 nM
Estimate against measurement, compound 4: 4.3-fold (0.63 log units) below, within the range that was stated.
By their numbers in this assay, from the lowest: compounds 2 and 1 (each within the scatter of the next); then compounds 3 and 4 (each within the scatter of the next).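

On this double-bonded chain carbon, the 4-chlorophenyl and the 3-(trifluoromethoxy)phenyl show no difference in this assay, with a 1.2-fold higher number from compound 3 to compound 4 (0.09 log units; within the scatter), although the two groups differ in their heavy atoms and hydrogen-bond acceptors. The high number of compound 3 is therefore not unique to the 3-(trifluoromethoxy)phenyl, for the 4-chlorophenyl also stands far from the 2-cyanophenyl, with a 38-fold higher number from compound 1 to compound 4 (1.58 log units; beyond the scatter), and from the 2-(trifluoromethyl)phenyl, with a 43-fold higher number from compound 2 to compound 4 (1.63 log units; beyond the scatter); none of the four compounds goes against this split into two pairs. No data on hand bear on what lies behind this split.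

The substituent's identity and its place on the ring change together across these pairs, so their separate contributions remain unresolved. Going by these compounds, how a plain phenyl at this chain carbon would compare with either pair also remains open.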